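A few compounds are considered here, and "the series" means these few. Any claim that something is new, unique, unknown or untested is made for them only; others in the source may bear on it.

Measured so far:
- compound 1, `O=C(C(Nc1ccccc1F)c1ccc(C(F)(F)F)cc1)N1CCCC1c1ccccc1F`, 7 nM in an assay on HEK293 cells for antagonist activity at transient receptor potential M8 protein (Canis lupus familiaris), read by fluorescence and calcium flux, with a stated time of 5 min; on this read-out lower numbers stand for stronger inhibition and higher numbers for weaker inhibition
- compound 2, `O=C(C(Nc1ccccc1F)c1ccc(C(F)(F)F)cc1)N1CCC[C@@H]1c1ccccc1F`, 44 nM in this assay

Within the data shown here, compound 2 stands as the weaker of the two numbers known; its nearest neighbour is compound 1, and the step of a 6.3-fold higher number from compound 1 to compound 2 (0.80 log units; beyond the scatter) lies beyond the scatter. The two differ only in how one stereocentre is drawn the fact that one of compounds 1 and 2 is drawn with a defined configuration and the other without, at the place where they differ: compound 1 leaves the ring carbon unassigned, so it stands for a mixture, while compound 2 fixes it as R.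

Compound 3 is `O=C([C@H](Nc1ccccc1F)c1ccc(C(F)(F)F)cc1)N1CCC[C@H]1c1ccccc1F`. It differs from compound 2 in this way: the two compounds have the same atoms and bonds; at least one stereo element is drawn with a configuration in one of them and without one in the other: 2 of 2 stereo elements differ; a stereocentre at a saturated chain carbon is drawn without a configuration in compound 2 and R in compound 3; a stereocentre at a saturated ring carbon is drawn R in compound 2 and S in compound 3. So compound 3 is a single, fully defined stereoisomer, and at the ring carbon it carries the configuration opposite to compound 2. Among the measured compounds shown here, the one step measured, from the mixture to the R ring isomer, weakened inhibition; the mixture in compound 1 must therefore contain a more potent component, and the S ring configuration in compound 3 is the candidate. Compound 3 is thus expected to be stronger than compound 2, a step estimated as an 8.8-fold lower number from compound 2 to compound 3 (0.94 log units; beyond the scatter), with the chain stereocentre, for which no comparison exists, as the main uncertainty. The estimate for compound 3 in this assay is 5 nM, with a range from 1 nM to 30 nM.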

Compound 3, half-maximal inhibitory concentration: 45 nM
Estimate against measurement, compound 3: 9.0-fold (0.95 log units) below; the measured number lies above the stated range.
By their numbers in this assay, from the lowest: compound 1; then compounds 2 and 3 (each within the scatter of the next).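

In this assay, turning the ring carbon from R to S while also fixing the chain carbon as R gives a 1.0-fold higher number from compound 2 to compound 3 (0.01 log units; within the scatter), so this double change leaves the reading level with compound 2 and the S ring carbon brings no gain in this pairing. Compared with the undefined compound 1, there is a 6.4-fold higher number from compound 1 to compound 3 (0.81 log units; beyond the scatter), so compound 3, a single stereoisomer, cannot by itself account for the stronger number of the mixture. Only the drawn stereochemistry separates these two: the fact that one of compounds 1 and 3 is drawn with a defined configuration and the other without, at the place where they differ

Which arrangement carries the strength of compound 1 stays open, with S at both the ring and chain carbons still a candidate and compound 2 still undefined at its chain carbon. Also open, from the compounds shown here alone, is whether a nitrile or a methoxy group in place of the trifluoromethyl group would keep inhibition in a fixed stereoisomer.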